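Swapping the sulfonyl aryl ring of a weak orexin blocker

The source may report more compounds than this note shows. Statements on the series, on what has been measured and on what is new or still open speak of the compounds shown alone.

Measured compounds:
compound 1, `CCN(CC)C(=O)CN(c1ccc(C)cc1)S(=O)(=O)c1cccc(F)c1`, 839 nM
compound 2, `CCN(CC)C(=O)CN(c1cc2c(C)nsc2cc1Cl)S(=O)(=O)c1ccc(OC)c(OC)c1`, 4.5 nM
compound 3, `CCN(CC)C(=O)CN(c1cc(C(C)C)ccc1Cl)S(=O)(=O)c1ccc(OC)c(OC)c1`, 90 nM

All three share a core in which a sulfonamide nitrogen carries an aryl group on one side and a sulfonyl-linked aryl ring on the other. In a functional assay on CHO cells for inhibition of Orexin receptor type 2 (Homo sapiens), read by FLIPR and calcium flux (on this read-out higher numbers stand for weaker inhibition and lower numbers for stronger inhibition), compound 1 gives 839 nM, the highest number of the three and so the weakest inhibitor here. Compound 2 and compound 3 are separated by a single change on the sulfonamide nitrogen, and that change gives a 20-fold higher number from compound 2 to compound 3 (1.30 log units; beyond the scatter). Compound 1 sits beyond compound 3 by a further sizable gap.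

Compound 4, `CCN(CC)C(=O)CN(c1ccc(C)cc1)S(=O)(=O)c1ccc(OC)cc1`, changes a different part of compound 1: 4-methoxyphenyl in place of 3-fluorophenyl on a sulfonyl sulfur. Going by the values given here, no measured pair differs at the sulfonyl sulfur alone, so the one measured step speaks to a different position and does not bear directly on this change. What remains is that compound 2 and compound 3, whose sulfonyl rings carry methoxy groups, sit far below compound 1 in this assay, though they also differ from compound 1 elsewhere, so their numbers cannot be credited to the sulfonyl ring alone. On that footing the expectation for compound 4 is a modest move toward stronger inhibition, a 2.1-fold lower number from compound 1 to compound 4 (0.32 log units; beyond the scatter), with wide uncertainty. Compound 4 is therefore estimated at 400 nM, ranging from 100 nM to 1500 nM.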

Compound 4, half-maximal inhibitory concentration: 661 nM
The estimate for compound 4 lay 1.7-fold (0.22 log units) below the measured number; the measured number falls inside the stated range.
By their numbers in this assay, from the lowest: compound 2; then compound 3; then compounds 4 and 1 (each within the scatter of the next).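

In this assay, going by these compounds alone, the step at the sulfonyl sulfur gives the first direct reading of this position: 4-methoxyphenyl in place of 3-fluorophenyl produces a 1.3-fold lower number from compound 1 to compound 4 (0.10 log units; within the scatter), so the two compounds cannot be told apart. Exchanging the fluorine-bearing ring for a methoxy-bearing ring, which also brings in a hydrogen-bond acceptor, therefore gives no detectable shift on the core of compound 1, and this single swap offers no support for crediting a large gain in inhibition to a methoxy group on the sulfonyl ring. Nothing available explains why the number holds steady across this change.

Still open, on these data alone, is whether a more different group on the sulfonyl sulfur, such as a pyridine ring or a phenyl ring carrying an amine or a carboxylic acid, would move the number beyond the scatter. It is also open whether the same swap would stay just as silent with the groups that compound 2 and compound 3 carry on the sulfonamide nitrogen, since the compounds shown offer no pair that tests this.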